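A few compounds are considered here, and "the series" means these few. Any claim that something is new, unique, unknown or untested is made for them only; others in the source may bear on it.

Working notes on the series in a functional assay on HeLa cells (Homo sapiens) for inhibition; a lower number here means a stronger inhibitor, a higher number a weaker inhibitor.

Compound 1 `CC(C)c1ccc(C(=O)CC(SCC(=O)O)C(=O)O)cc1` gives 3330 nM in this assay. Compound 2 `CCCCc1ccc(C(=O)CC(SCC(=O)O)C(=O)O)cc1` gives 1920 nM in this assay, and compound 3 `O=C(O)CSC(CC(=O)c1ccc(Br)cc1)C(=O)O` gives 9500 nM in this assay. Among these three numbers compound 1 stands second highest. The step from compound 1 to compound 2 is a 1.7-fold lower number from compound 1 to compound 2 (0.24 log units; within the scatter), while the step from compound 1 to compound 3 is a 2.9-fold higher number from compound 1 to compound 3 (0.46 log units; beyond the scatter) and the step from compound 2 to compound 3 is a 4.9-fold higher number from compound 2 to compound 3 (0.69 log units; beyond the scatter). So, within the measured set, exchanging the isopropyl for butyl changes little and exchanging it for bromo gives a modest weakening.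

Compound 4 `CC(C)c1ccc(C(=O)CC(SCC(=O)O)C(=O)O)c(C(C)C)c1` differs from compound 1 by isopropyl in place of hydrogen on an aromatic carbon. Within the data shown here, no measured step describes adding a second group of this kind; the measured steps only compare one group against another at the same place. The nearest guide is the isopropyl-to-butyl comparison, in which a larger alkyl group left the number essentially unchanged. The expected step of a 1.1-fold lower number from compound 1 to compound 4 (0.05 log units; within the scatter) is therefore small, with no direction beyond the scatter. Compound 4 is estimated at 3000 nM, expected within 1000 nM to 10000 nM.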

Compound 4, half-maximal inhibitory concentration: 1100 nM
For compound 4 the middle estimate is 2.7-fold (0.44 log units) above the measured one, and the stated range covers the measured number.
By their numbers in this assay, from the lowest: compounds 4, 2 and 1 (each within the scatter of the next, the first and the last beyond it); then compound 3.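

In this assay, isopropyl in place of hydrogen on an aromatic carbon, ortho to a large group and meta to an isopropyl group, gives a 3.0-fold lower number from compound 1 to compound 4 (0.48 log units; beyond the scatter) and so shows that this position can carry a group without the number rising. The earlier steps shown here only exchanged one group for another at a single place on the aromatic ring, whereas this step fills a hydrogen-bearing carbon and yields a modest strengthening. Nothing at hand accounts for this gain.

Open, going by these compounds, is whether a methyl, a methoxy group or an amine in place of that hydrogen would give a step of similar size and direction. Also open, on these data alone, is whether the same isopropyl addition would lower the number in the same way on compound 2 or on compound 3.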